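The compounds below may be only part of what the source reports. "The series", "measured", "known", "first", "only" and "open" are said of these compounds alone.

In an assay on HEK293 cells for inhibition of Voltage-dependent T-type calcium channel subunit alpha-1G (Homo sapiens), read by patch clamp, tested at 10 uM (on this read-out higher numbers stand for more inhibition at the one concentration tested (going by the name of the read-out) and lower numbers for less inhibition), the three measured compounds stand as follows:

Compound 1 `O=C(CCCN1CCN(c2ccccc2)CC1)Nc1ccc(Cl)cc1` gives 75.1%.
Compound 2 `O=C(CCCN1CCN(c2ccccc2F)CC1)Nc1ccc(Cl)cc1` gives 79.2%.
Compound 3 `O=C(CCCN1CCN(c2ccccc2Cl)CC1)Nc1ccc(Cl)cc1` gives 60.5%.

Compound 3 is the lowest of the three. Compounds 1 and 2 sit close together, a number 4.1 percentage points higher from compound 1 to compound 2 (within the scatter), while compound 3 falls clearly below both: a number 14.6 percentage points lower from compound 1 to compound 3 (beyond the scatter) and a number 18.7 percentage points lower from compound 2 to compound 3 (beyond the scatter).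

Compound 4 `O=C(CCCN1CCN(c2ccc(Cl)cc2)CC1)Nc1ccc(Cl)cc1` keeps the same atoms as compound 3 but joins them differently: 4-chlorophenyl in place of 2-chlorophenyl on an amine nitrogen in a ring. Among the measured compounds shown here, no measured pair shows a chloro moved from one place on this ring to another, so the only steps that bear on it are those in which a chloro arrived on the 2-position of the ring, a number 14.6 percentage points lower from compound 1 to compound 3 (beyond the scatter) and a number 18.7 percentage points lower from compound 2 to compound 3 (beyond the scatter), both modest drops. Whether a chloro on the 4-position behaves like one on the 2-position, or like none at all, the data do not tell. Compound 4 is therefore expected to land between compound 3 and compound 1, with the estimate 70% in a range from 52% to 88%. This estimate means an expected step of a number 9.5 percentage points higher from compound 3 to compound 4 (within the scatter), upward but possibly within the scatter.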

Compound 4, a percentage reported as inhibition, at one concentration (the size of the read-out at that concentration, not a potency): 94.6%
Estimate against measurement, compound 4: 24.6 percentage points below; measured number above the stated range.
By their numbers in this assay, from the lowest: compound 3; then compounds 1 and 2 (each within the scatter of the next); then compound 4.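

Moving the chloro, with no change in the atoms present, gives a number 34.1 percentage points higher from compound 3 to compound 4 (beyond the scatter) in this assay, so on this ring the place of the chloro matters, not only its presence. A chloro can therefore pull the number either way: 2-chlorophenyl sits lower than the plain phenyl, whereas 4-chlorophenyl gives a number 19.5 percentage points higher from compound 1 to compound 4 (beyond the scatter) and also a number 15.4 percentage points higher from compound 2 to compound 4 (beyond the scatter), the highest number of the four, beyond the scatter of each of the others. Nothing measured here explains why the two placements differ so much.

Still open, going by these compounds, is whether the rise belongs to chloro itself, or whether a methoxy or trifluoromethyl group in the place of that chloro would give a similar number. On these data alone, it is equally open whether the same order of compounds would hold with a longer chain in the shared core.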